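The source may hold more compounds than are shown below. What is called first, only, known or untested is meant among the compounds shown, and "the series" means these compounds.

Compound 1 `COc1ccccc1-c1nnc(-c2ccc(C(=O)N/N=C/c3ccc(Cl)cc3Cl)cc2)o1`: 75600 nM
Compound 2 `COc1ccccc1-c1nnc(-c2ccc(C(=O)N/N=C/c3c(O)cc(O)cc3O)cc2)o1`: 15200 nM

In an ADME assay on U-937 cells (Homo sapiens) for cytotoxicity (a higher number here means a weaker inhibitor, a lower number a stronger inhibitor), compound 2 holds the lower of the two numbers; the step of a 5.0-fold lower number from compound 1 to compound 2 (0.70 log units; beyond the scatter) separates it from compound 1. Compound 3 `COc1ccccc1-c1nnc(-c2ccc(C(=O)N/N=C/c3ccccn3)cc2)o1` carries pyridin-2-yl in place of 2,4,6-trihydroxyphenyl on a carbon with a double bond to nitrogen. Among the measured compounds shown here, the only measured step, a 5.0-fold lower number from compound 1 to compound 2 (0.70 log units; beyond the scatter), shows that the group on that carbon shifts this assay by a modest amount, but no measured step involves pyridin-2-yl. A modest move back toward the number of compound 1 is therefore expected, if any beyond the scatter. Compound 3 is expected to give 35000 nM, between 12000 nM and 100000 nM. The expected step is a 2.3-fold higher number from compound 2 to compound 3 (0.36 log units; beyond the scatter).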

Compound 3, half-maximal inhibitory concentration: 68600 nM
Estimate against measurement, compound 3: 2.0-fold (0.29 log units) below, within the range that was stated.
By their numbers in this assay, from the lowest: compound 2; then compounds 3 and 1 (each within the scatter of the next).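

In this assay, pyridin-2-yl on this carbon does not keep the lower number of the 2,4,6-trihydroxyphenyl group, as a 4.5-fold higher number from compound 2 to compound 3 (0.65 log units; beyond the scatter) shows. Against 2,4-dichlorophenyl, the change gives a 1.1-fold lower number from compound 1 to compound 3 (0.04 log units; within the scatter) and so cannot be told apart, leaving compound 2 alone among these three compounds. Nothing available explains this separation. Still open, on these data alone, is whether the lower number needs all the hydroxyl groups of compound 2, and where a phenyl ring carrying an amine or a carboxylic acid on this carbon would fall.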